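Aziridinylquinone series: replacing the carbamate chain with cyclohexyl

A few compounds are considered here, and "the series" means these few. Any claim that something is new, unique, unknown or untested is made for them only; others in the source may bear on it.

Measured compounds and their values:
- compound 1 `CC1=C(N2CC2)C(=O)C(Cc2ccccc2)=C(N2CC2)C1=O`: 4.85
- compound 2 `CC1=C(N2CC2)C(=O)C(CCCOC(N)=O)=C(N2CC2)C1=O`: 6.18
- compound 3 `CC1=C(N2CC2)C(=O)C(CCCc2ccccc2)=C(N2CC2)C1=O`: 4.47

In a functional assay on L1210 cells (Mus musculus), with a stated time of 12 days (on this read-out lower numbers stand for lower potency and higher numbers for higher potency (the scale is a negative logarithm)), compound 2 gives the highest of the three numbers; compound 1 sits at 4.85 and compound 3 at 4.47, both beyond the scatter below it. Compound 4 `CC1=C(N2CC2)C(=O)C(C2CCCCC2)=C(N2CC2)C1=O` is not yet measured; it differs from compound 2 in one place: a group of 6 heavy atoms (6 carbon; one six-membered non-aromatic ring of carbon only) in place of a group of 7 heavy atoms (4 carbon, 1 nitrogen, 2 oxygen; no ring), on a double-bonded ring carbon.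

For the measured compounds named here, two measured steps bear on this. The loss of the carbamate gave a number 1.71 log units lower from compound 2 to compound 3 (beyond the scatter), and its introduction gave a number 1.33 log units higher from compound 1 to compound 2 (beyond the scatter). Both place the hydrocarbon-bearing compounds far below compound 2, and compound 4 carries only carbon on the ring carbon in question. A large drop is therefore expected, about a number 1.48 log units lower from compound 2 to compound 4 (beyond the scatter), toward the values of compounds 1 and 3. Compound 4 is estimated at 4.7, with a range from 4.2 to 5.2.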

Compound 4, logarithm of the reciprocal of the active concentration, log(1/C): 5.82
For compound 4 the middle estimate is 1.12 log units below the measured one; the whole stated range lies below it.
By their numbers in this assay, from the lowest: compound 3; then compound 1; then compound 4; then compound 2.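

In this assay, a group of carbon only on this double-bonded ring carbon need not give a low number: cyclohexyl in place of the carbamate chain gives only a modest loss, a number 0.36 log units lower from compound 2 to compound 4 (beyond the scatter). Cyclohexyl in place of benzyl gives a number 0.97 log units higher from compound 1 to compound 4 (beyond the scatter), so groups of carbon only differ widely here, and compound 1 and compound 3 go against any rule that such groups give high numbers. Nothing on hand accounts for either step.

Open, from the compounds shown here alone, is whether the closed ring itself matters, which an open hexyl chain or a cyclopentyl ring on the same carbon would test. Also open, going by these compounds, is how an amine at the end of the chain would compare with the carbamate.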